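A second chloro on the fused core of compound 3

The source may report more compounds than this note shows. Statements on the series, on what has been measured and on what is new or still open speak of the compounds shown alone.

Three compounds share a fused two-ring core carrying a chloromethyl-substituted benzyl group, and all three were tested in a functional assay on RXF 393 cells (Homo sapiens) for cytotoxicity, read by sulforhodamine B assay, with a stated time of 48 h; a higher number here means a weaker inhibitor of growth, a lower number a stronger inhibitor of growth. Compound 1 `ClCc1ccc(Cn2cnc3c(Cl)ncnc32)cc1` gives 2300 nM in this assay. Compound 2 `ClCc1ccccc1Cn1cnc2c(Cl)ncnc21` gives 440 nM in this assay. Compound 3 `ClCc1cccc(Cn2cnc3c(Cl)ncnc32)c1` gives 2290 nM in this assay. Among these three numbers compound 3 stands second highest: compound 1 sits closest, and the two lie within the scatter of each other, so no order between them can be read; compound 2 gives a number lower by a margin beyond the scatter.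

The step under consideration leads from compound 3 to compound 4 `ClCc1cccc(Cn2cnc3c(Cl)nc(Cl)nc32)c1`, which has not yet been measured in this assay. The change is chloro in place of hydrogen on an aromatic carbon. Among the compounds with values here, no measured pair in this set shows the same change, so its effect is open. A single added chloro on the core is a small alteration, and the account expects at most a modest shift. The estimate is that a 1.4-fold lower number from compound 3 to compound 4 (0.16 log units; within the scatter) lies within or just beyond the scatter, tending toward a lower number. For compound 4 the expected value in this assay is 1600 nM, with a range from 600 nM to 4500 nM.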

Compound 4, concentration for 50% growth inhibition: 750 nM
Estimate against measurement, compound 4: 2.1-fold (0.33 log units) above; low and high end bracket the measured number.
By their numbers in this assay, from the lowest: compounds 2 and 4 (each within the scatter of the next); then compounds 3 and 1 (each within the scatter of the next).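

In this assay the chloro on the aromatic carbon between two ring nitrogen atoms gives a 3.1-fold lower number from compound 3 to compound 4 (0.48 log units; beyond the scatter) and so moves the number beyond the scatter, which shows that this carbon of the core is not a silent position. Within the data shown here, compounds 1, 2 and 3 all carry hydrogen on this carbon and differ only in where the chloromethyl group sits on the benzyl group, so they could say nothing about a change on the core itself; this step is the first reading of one, and it comes from an entering group of a single heavy atom with no hydrogen-bond donors or acceptors. The shift rests on this one pair, and nothing at hand accounts for it.

Going by these compounds, whether an amine, a methoxy group or a longer chain on the same carbon would lower the number as the chloro does, or leave it unchanged, remains open. Also open, on these data alone, is whether the same chloro in place of hydrogen would give a step of similar size on compound 1 or compound 2, where the chloromethyl group sits elsewhere.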